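A few compounds are considered here, and "the series" means these few. Any claim that something is new, unique, unknown or untested is made for them only; others in the source may bear on it.

Three compounds share one core and differ in the group on the ring nitrogen and in the substitution of the other aromatic ring. Compound 1 `O=C1Nc2ccccc2/C1=C\c1c(Cl)n(Cc2ccccc2)c2ccccc12` gives 20900 nM in a functional assay on cells (Cancer cell lines, Homo sapiens) for cytotoxicity, with a stated time of 48 h; on this read-out higher numbers stand for weaker inhibition of growth and lower numbers for stronger inhibition of growth. Compound 2 `O=C1Nc2ccccc2/C1=C\c1c(Cl)n(CCCc2ccccc2)c2ccccc12` gives 12000 nM, and compound 3 `COc1ccc2c(c1)/C(=C\c1c(Cl)n(C/C=C/c3ccccc3)c3ccccc13)C(=O)N2` gives 2090 nM. Among these three numbers compound 2 stands second highest: compound 1 is its nearest neighbour, and compound 3 lies furthest from it. Going by the values given here, the only single-point step measured so far is a 1.7-fold lower number from compound 1 to compound 2 (0.24 log units; within the scatter), and that step concerns the chain on the nitrogen, not the aromatic ring.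

Compound 4 `O=C1Nc2ccc(Cl)cc2/C1=C\c1c(Cl)n(CCCc2ccccc2)c2ccccc12` is not yet measured. It differs from compound 2 by chloro in place of hydrogen on an aromatic carbon. Among the compounds with values here, no measured step touches this ring directly; compound 3 carries a different group on that ring together with a different chain, so it offers no isolated comparison. Only a modest shift is therefore expected, on the order of a 1.5-fold lower number from compound 2 to compound 4 (0.18 log units; within the scatter). Compound 4 is estimated at 8000 nM, within a range from 3000 nM to 20000 nM.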

Compound 4, concentration for 50% growth inhibition: 2450 nM
Beside the measured number, compound 4's estimate is 3.3-fold (0.51 log units) above it; the measured number lies below the stated range.
By their numbers in this assay, from the lowest: compounds 3 and 4 (each within the scatter of the next); then compounds 2 and 1 (each within the scatter of the next).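

In this assay, going by these compounds alone, chloro in place of hydrogen on an aromatic carbon gives a 4.9-fold lower number from compound 2 to compound 4 (0.69 log units; beyond the scatter) and so produces the first single-point step here that lies beyond the scatter. The only earlier step, a 1.7-fold lower number from compound 1 to compound 2 (0.24 log units; within the scatter), concerned the chain on the nitrogen and stayed within the scatter, so this ring position, meta to a fused ring and para to a fused ring, is the first place shown where one added heavy atom clearly moves the number. Nothing shown gives a cause for this shift.

Going by these compounds, whether bromo, a nitrile or an amine at the same position would move the number in the same direction remains open. It is also unknown whether chloro would give a similar step with the shorter chain of compound 1.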